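This account rests on a few compounds, and the source may have more. Where it says the series, first, only, none or still open, it means among the compounds named here.

In an assay on isolated protein for inhibition of Indoleamine 2,3-dioxygenase 1 (Homo sapiens), read by spectrophotometry, with a stated time of 1 h (on this read-out lower numbers stand for stronger inhibition and higher numbers for weaker inhibition), compound 1 `O=[N+]([O-])c1ccc(N/C(=N\O)c2ccccc2Cl)c2nonc12` gives 135 nM, compound 2 `O=[N+]([O-])c1ccc(N/C(=N\O)c2cccc(F)c2)c2nonc12` gives 75 nM and compound 3 `O=[N+]([O-])c1ccc(N/C(=N\O)c2ccc(F)cc2)c2nonc12` gives 100 nM. Compound 2 has the lowest of the three numbers, yet the steps of a 1.8-fold lower number from compound 1 to compound 2 (0.26 log units; within the scatter) and a 1.3-fold higher number from compound 2 to compound 3 (0.12 log units; within the scatter) both fall within the scatter, as does a 1.4-fold lower number from compound 1 to compound 3 (0.13 log units; within the scatter), so no order among the three is secured. Compound 4 `O=[N+]([O-])c1ccc(N/C(=N\O)c2ccc(Br)cc2)c2nonc12` is the next member; the change from compound 2 is 4-bromophenyl in place of 3-fluorophenyl on a carbon with a double bond to nitrogen. Among the compounds with values here, only the moves among halogen-bearing phenyl rings bear on it, and each of them stayed within the scatter; no measured pair separates bromine from fluorine on the ring. A step beyond the scatter is therefore not expected in this assay for compound 4, the expected step of a 1.2-fold higher number from compound 2 to compound 4 (0.08 log units; within the scatter) being small. The estimate for compound 4 in this assay is 90 nM, with a range from 40 nM to 220 nM.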

Compound 4, half-maximal inhibitory concentration: 117 nM
For compound 4 the middle estimate is 1.3-fold (0.11 log units) below the measured one; low and high end bracket the measured number.
By their numbers in this assay, from the lowest: compounds 2, 3, 4 and 1 (each within the scatter of the next).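

Bromo in place of fluoro on an aromatic carbon (a 1.2-fold higher number from compound 3 to compound 4 (0.07 log units; within the scatter)) leaves the number within the scatter, and this is the only step in the set confined to the halogen itself. The steps from the other two compounds (a 1.6-fold higher number from compound 2 to compound 4 (0.19 log units; within the scatter); a 1.2-fold lower number from compound 1 to compound 4 (0.06 log units; within the scatter)) also stay within the scatter, so the 4-bromophenyl group is not separated from the other halogen-bearing phenyl rings on this carbon. Nothing available explains these small steps. Still open, from the compounds shown here alone, is whether an amine or a carboxylic acid on the phenyl ring would give a step beyond the scatter.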